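From benzyl to 4-methoxybenzyl in compound 1

This account rests on a few compounds, and the source may have more. Where it says the series, first, only, none or still open, it means among the compounds named here.

In a functional assay on A549 cells (Homo sapiens) for inhibition, read by sulforhodamine B assay, with a stated time of 72 h (on this read-out lower numbers stand for stronger inhibition and higher numbers for weaker inhibition), compound 1 (`COc1ccc(CN(Cc2ccccc2)Cc2c(O)ccc3c(=O)cc(C)oc23)cc1`) gives 14.1 ug/mL and compound 2 (`COc1ccc(CN(Cc2ccc([N+](=O)[O-])cc2)Cc2c(O)ccc3c(=O)cc(C)oc23)cc1`) gives 24.5 ug/mL. Among the measured compounds shown here, these are the only two numbers so far, and they lie within the usual scatter of each other, so compound 1 has no clear standing yet. Compound 3 (`COc1ccc(CN(Cc2ccc(OC)cc2)Cc2c(O)ccc3c(=O)cc(C)oc23)cc1`) is still unmeasured. It differs from compound 1 by methoxy in place of hydrogen on an aromatic carbon, which is methoxy in place of hydrogen on an aromatic carbon, turning benzyl into 4-methoxybenzyl. For the measured compounds named here, the only measured step that bears on this swaps in nitro instead, and it shows a 1.7-fold higher number from compound 1 to compound 2 (0.24 log units; within the scatter). That single step, with a different group, gives compound 3 no reason to move beyond the scatter. The expected change is small, an estimated 1.1-fold higher number from compound 1 to compound 3 (0.05 log units; within the scatter). For compound 3 the estimated value in this assay is 16 ug/mL, with an expected range of 8 ug/mL to 32 ug/mL.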

Compound 3, half-maximal inhibitory concentration: 62.5 ug/mL
Compound 3: middle estimate off by 3.9-fold (0.59 log units), on the low side; the measured number lies above the stated range.
By their numbers in this assay, from the lowest: compounds 1 and 2 (each within the scatter of the next); then compound 3.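

In this assay, this place on the ring turns out not to be indifferent to what sits there: methoxy in place of hydrogen gives a 4.4-fold higher number from compound 1 to compound 3 (0.65 log units; beyond the scatter), a modest loss of inhibition. Methoxy in place of nitro gives a 2.6-fold higher number from compound 2 to compound 3 (0.41 log units; beyond the scatter), also modest, so methoxy stands apart from both hydrogen and nitro, even though those two lie within the scatter of each other. Nothing measured here explains why methoxy differs from the other two groups.

The compounds shown leave open whether this loss is particular to methoxy or also appears with other groups at this place, such as hydroxy, an amine or a carboxylic acid. They also leave open whether a longer chain, such as ethoxy, would give a higher or lower number than methoxy.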